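Replacing phenyl with (phenylsulfanyl)methyl on a chain carbon

This account rests on a few compounds, and the source may have more. Where it says the series, first, only, none or still open, it means among the compounds named here.

Of the compounds shown here, three have so far been tested in a functional assay on the whole organism with Rattus norvegicus as the target; a higher number here means that more compound is needed for the effect, a lower number that less compound is needed. Compound 1, `Nc1nc2ccc(C3CCCCC3)cc2s1`, gives > 10 mg/kg, which is a limit of the assay rather than a number. Compound 2, `CC(C)(C)Cc1ccc2nc(N)sc2c1`, gives > 10 mg/kg, again a limit. Compound 3, `N=c1sc2cc(OC(F)(F)F)ccc2n1Cc1ccccc1`, gives > 10 mg/kg in this assay, also a limit. Compound 3 therefore stands exactly where all the measured values stand: the limit of > 10 mg/kg in this assay, at which 3 of the 3 values shown sit. No two of these three compounds differ in only one place, so no step between measured compounds can be read off, and none of the three can be set apart from the others on the numbers shown.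

Compound 4, `N=c1sc2cc(OC(F)(F)F)ccc2n1CCSc1ccccc1`, is the next compound to be measured. It differs from compound 3 in a single place: (phenylsulfanyl)methyl in place of phenyl on a saturated chain carbon bound to an aromatic nitrogen. The change keeps the six-membered aromatic ring of carbon only, and adds one hydrogen-bond acceptor on the chain that leads to the aromatic nitrogen.

Since every measured value sits at the same limit, the data give no foothold for a change in either direction. The step expected here, a step that the limit leaves unreadable from compound 3 to compound 4, is estimated as none beyond the scatter. Compound 4 is expected to give about 15 mg/kg in this assay, within a range from 5 mg/kg to 50 mg/kg, and most likely it will again be reported only as a limit.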

Compound 4, dose for half-maximal effect: 4.5 mg/kg
Compound 4: the middle estimate sits 3.3-fold (0.52 log units) above what was measured, and the stated range ends above it.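

In this assay, putting (phenylsulfanyl)methyl in place of phenyl on a saturated chain carbon bound to an aromatic nitrogen gives an at least 2.2-fold lower number from compound 3 to compound 4 (0.34 log units; beyond the scatter). For the compounds shown here, this is the first change whose effect can be read at all, and it shows that this chain position responds to what is attached there, with the shared core left untouched. Compound 4 is also the only compound shown with a measured number rather than a limit, so it gives the series its first real reference point, while the other three remain at the limit: the limit of > 10 mg/kg in this assay, at which 3 of the 4 values shown sit.

The change adds a sulfur atom and also moves the phenyl ring further along the chain, and the compounds shown cannot say which of these two matters, or whether both do. Going by these compounds, an all-carbon chain in place of the sulfur-bearing one would help separate them, as would an ether oxygen or an amine at the sulfur's place, and it remains open whether a still longer chain would lower the number further.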